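The source may hold more compounds than are shown below. What is called first, only, known or untested is meant among the compounds shown, and "the series" means these compounds.

Measured so far:
compound 1 `COc1ccc(F)c(-c2ccc(C(=O)N(Cc3cccc(OCCCCCC(=O)O)c3)C(C)C)cc2)c1` — in an ADME assay on BJ cells (Homo sapiens) for cytotoxicity, read by CellTiter-Glo and resazurin assay, with a stated time of 72 h (a lower number here means that less compound is needed, a higher number that more compound is needed for the effect), compound 1 gives only a limit, > 26000 nM.
compound 2 `CCOC(=O)CCCCCOc1cccc(CN(C(=O)c2ccc(-c3ccncc3)cc2)C(C)C)c1` — in this assay compound 2 gives only a limit, > 26000 nM.
compound 3 `CCOC(=O)CCCCCOc1cccc(CN(C(=O)c2ccc(-c3cccc(Oc4ccccc4)c3)cc2)C(C)C)c1` — in this assay compound 3 gives only a limit, > 19600 nM.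

Compound 2 therefore cannot be ranked: its result is a limit, not a number, and its two companions fare the same, two of the three results sitting at the limit of > 26000 nM in this assay, at which 2 of the 3 values shown sit, and one at the limit of > 19600 nM in this assay, at which 1 of the 3 values shown sits. Compound 4 `CCOC(=O)CCCCCOc1cccc(CN(C(=O)c2ccc(-c3ccc4[nH]ccc4c3)cc2)C(C)C)c1` has not yet been tested in this assay. It differs from compound 2 in one place: 1H-indol-5-yl in place of pyridin-4-yl on an aromatic carbon. Among the compounds with values here, no measured pair differs in a single place, so no step can be leaned on. With every result resting at the limit of > 26000 nM in this assay, at which 2 of the 3 values shown sit, or (the limit of > 19600 nM in this assay, at which 1 of the 3 values shown sits), the expected step is a step that the limit leaves unreadable from compound 2 to compound 4, nothing beyond the scatter. Compound 4 is expected to give 30000 nM, within 10000 nM to 100000 nM, most likely again as a limit.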

Compound 4, half-maximal effective concentration: > 26000 nM
Compound 4 ended at the assay's limit; the forecaster's own chance of this, stated with the estimate: 85%; the middle value does not contradict the limit.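

Compound 2 and compound 4 each give only a limit, not a number, and the step between them cannot be read. The compounds shown leave open at what concentration, if any, each would show an effect in this assay.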